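Methoxy entering the aryl ring of the cyclopropane amide

The source may report more compounds than this note shows. Statements on the series, on what has been measured and on what is new or still open speak of the compounds shown alone.

Notes on the series. Within the data shown here, compound 1 `CC(C)(C)c1ccc(CNC(=O)C(C)(C)c2ccc(NS(C)(=O)=O)c(F)c2)cc1` and compound 2 `CC(C)(C)c1ccc(CNC(=O)C2(c3ccc(NS(C)(=O)=O)cc3)CC2)cc1` share the amide linked to the tert-butylbenzyl group and differ in more than one place, so no single step connects them. In an assay on CHO cells for displacement of a labelled ligand from transient receptor potential cation channel subfamily V member 1 (Rattus norvegicus) (on this read-out lower numbers stand for stronger inhibition and higher numbers for weaker inhibition), compound 1 gives 1070 nM. In this assay compound 2 gives 610 nM, the lower of the two numbers, though the value of compound 1 lies within the usual scatter of it, so the two cannot be ranked.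

Compound 3 `COc1cc(C2(C(=O)NCc3ccc(C(C)(C)C)cc3)CC2)ccc1NS(C)(=O)=O` has not been measured. Its difference from compound 2 is methoxy in place of hydrogen on an aromatic carbon. Among the measured compounds shown here, nothing in the measured pair isolates this change, so no measured step can be quoted for it. The expectation is a step of small size from compound 2 to compound 3, if any, toward a somewhat higher number, with nothing beyond the scatter ruled in or out, that is a 1.5-fold higher number from compound 2 to compound 3 (0.17 log units; within the scatter). For compound 3 in this assay the estimate is 900 nM, with a range from 300 nM to 3000 nM.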

Compound 3, inhibition constant: 750 nM
For compound 3 the middle estimate is 1.2-fold (0.08 log units) above the measured one; the range from low to high includes it.
By their numbers in this assay, from the lowest: compounds 2, 3 and 1 (each within the scatter of the next).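

Among these compounds, the step from hydrogen to methoxy, on the aromatic carbon ortho to the methanesulfonamido group, is the first that isolates a single place, and in this assay it reads as a 1.2-fold higher number from compound 2 to compound 3 (0.09 log units; within the scatter). Compound 2 and compound 3 therefore cannot be ranked, and this position carries a methoxy group with a value that cannot be told apart from that of the hydrogen compound, something the earlier pair, differing in more than one place, could not show. No supporting data bear on why the methoxy step is this small, so the result stands as an observation without an explanation.

Open, on these data alone, is whether this tolerance extends beyond methoxy, for example to hydroxy, ethoxy, a longer alkoxy chain, an amine or a carboxylic acid at the same position, where only a further single-place step could give an answer. Also open, as far as these compounds go, is whether methoxy would read the same way in the core of compound 1, which has two methyl groups on the carbon that carries the amide.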